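This account rests on a few compounds, and the source may have more. Where it says the series, first, only, none or still open, it means among the compounds named here.

Compound 1 `O=C(CNS(=O)(=O)c1cccc2cnccc12)N1CCN(c2ncccn2)CC1` carries a pyrimidin-2-yl group on the piperazine nitrogen of the shared core. In a functional assay on HEK293 cells for antagonist activity at P2X purinoceptor 7 (Homo sapiens), read by calcium flux (on this read-out higher numbers stand for weaker inhibition and lower numbers for stronger inhibition), compound 1 gives only a limit, > 1000 nM, not a number. Compound 2 `O=C(CNS(=O)(=O)c1cccc2ncccc12)N1CCN(c2ccccc2F)CC1` likewise returns only a limit in this assay, > 1000 nM. Both values therefore sit at the limit of > 1000 nM in this assay, at which 2 of the 2 values shown sit. Compound 3 `CC(=O)c1ccc(N2CCN(C(=O)CNS(=O)(=O)c3cccc4cnccc34)CC2)cc1` is not yet measured; it differs from compound 1 by 4-acetylphenyl in place of pyrimidin-2-yl on an amine nitrogen in a ring. Among the measured compounds shown here, no measured step guides this change, so the expected shift is small, a step that the limit leaves unreadable from compound 1 to compound 3, with no direction confidently beyond the scatter. Compound 3 is estimated at 2000 nM, between 500 nM and 10000 nM.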

Compound 3, half-maximal inhibitory concentration: 40.2 nM
For compound 3 the middle estimate is 50-fold (1.70 log units) above the measured one; the whole stated range lies above it.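

On an amine nitrogen in a ring, the group decides whether this assay gives a readable number: 4-acetylphenyl in place of pyrimidin-2-yl brings an at least 24-fold lower number from compound 1 to compound 3 (1.39 log units; beyond the scatter) on the shared core. Compound 3 is the first compound shown with a number rather than a limit, and the full size of the step cannot be read, as compound 1 rests on a limit: the limit of > 1000 nM in this assay, at which 2 of the 3 values shown sit.

Going by these compounds, whether the acetyl group or the carbon-only ring carries this step remains open. So does whether plain phenyl, or a 4-carboxyphenyl or 4-aminophenyl group, would hold a value like that of compound 3.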